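Swapping a phenyl for a formyl on a triazole-linked enone

The compounds below may be only part of what the source reports. "The series", "measured", "known", "first", "only" and "open" are said of these compounds alone.

Measured compounds:
- compound 1, `COc1cc(/C=C/C(C)=O)ccc1OCc1cn(-c2c(Cl)cccc2Cl)nn1`: 26600 nM
- compound 2, `COc1cc(/C=C/C(C)=O)ccc1OCc1cn(-c2ccc(-c3ccccc3)cc2)nn1`: 65400 nM

Of the compounds shown here, two sharing one core have been measured in a functional assay on MCF7 cells (Homo sapiens) for antiproliferative activity, read by MTT assay, with a stated time of 48 h; on this read-out higher numbers stand for weaker inhibition and lower numbers for stronger inhibition. Compound 1 gives 26600 nM in this assay, and compound 2 gives 65400 nM. Compound 2 therefore stands at the higher of the two numbers, and the gap to compound 1 lies beyond the usual scatter of this assay. Both compounds inhibit proliferation only weakly.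

The next compound, compound 3, `COc1cc(/C=C/C(C)=O)ccc1OCc1cn(-c2ccc(C=O)cc2)nn1`, is still to be measured in this assay. It differs from compound 2 in one place: formyl in place of phenyl on an aromatic carbon. For the measured compounds named here, no measured pair shows this kind of exchange, so the size of the step cannot be read from the data. A modest move toward a lower number is expected, of a size close to the scatter, described by the step of a 1.6-fold lower number from compound 2 to compound 3 (0.21 log units; within the scatter). On this basis compound 3 is estimated to give 40000 nM in this assay, with a likely range from 12000 nM to 130000 nM.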

Compound 3, half-maximal inhibitory concentration: 86400 nM
The estimate for compound 3 lay 2.2-fold (0.33 log units) below the measured number; measured number inside the range.
By their numbers in this assay, from the lowest: compound 1; then compounds 2 and 3 (each within the scatter of the next).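

In this assay, putting formyl in place of phenyl on an aromatic carbon gives a 1.3-fold higher number from compound 2 to compound 3 (0.12 log units; within the scatter), so at this position a six-membered aromatic ring of carbon only and a formyl of two heavy atoms cannot be told apart on this read-out. The whole group on the aromatic nitrogen does matter in this small set: 4-formylphenyl in place of 2,6-dichlorophenyl gives a 3.2-fold higher number from compound 1 to compound 3 (0.51 log units; beyond the scatter), a modest step beyond the scatter, which leaves compound 1 with the lowest number of the three. Nothing measured here accounts for the size of either step.

The compounds shown leave open whether an amine, a carboxylic acid or a longer alkyl chain on that same aromatic carbon would separate from phenyl and formyl on this read-out. They also leave open whether formyl in place of a chlorine on the 2,6-dichlorophenyl group would produce a step of similar size, and whether any change at this position can bring the number well below those seen so far.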